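The source may report more compounds than this note shows. Statements on the series, on what has been measured and on what is new or still open speak of the compounds shown alone.

Measured so far:
compound 1 `O=C(O)c1ccc(C(=O)/C(=C\c2ccc(Cl)c([N+](=O)[O-])c2)SCc2ccc(C(F)(F)F)cc2)cc1`: 1000 nM
compound 2 `O=C(O)c1ccc(C(=O)/C(=C\c2ccc(Br)c([N+](=O)[O-])c2)SCc2ccc(Br)cc2)cc1`: 1000 nM

In a functional assay on DU-145 cells (Homo sapiens) for inhibition, read by trypan blue exclusion, with a stated time of 96 h (a lower number here means a stronger inhibitor of growth, a higher number a weaker inhibitor of growth), compound 1 gives 1000 nM and compound 2 gives 1000 nM; compound 2 stands level with compound 1 at the digits shown, within the scatter. Compound 3 `O=C(O)c1ccc(C(=O)/C(=C\c2ccc(O)c(Br)c2)SCc2ccc(Br)cc2)cc1` has not been run in this assay. It differs from compound 2 by 3-bromo-4-hydroxyphenyl in place of 4-bromo-3-nitrophenyl on a double-bonded chain carbon bound to a double-bonded chain carbon. For the measured compounds named here, no step of this kind has been measured here, and the two aryl variants known give the same reading, so the expected step of a 1.1-fold higher number from compound 2 to compound 3 (0.04 log units; within the scatter) is none beyond the scatter. Compound 3 is estimated at 1100 nM, range 400 nM to 3000 nM.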

Compound 3, concentration for 50% growth inhibition: 25000 nM
The estimate for compound 3 lay 23-fold (1.36 log units) below the measured number; measured number outside the range, above it.
By their numbers in this assay, from the lowest: compounds 1 and 2 (each within the scatter of the next); then compound 3.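

In this assay, the aryl group on a double-bonded chain carbon bound to a double-bonded chain carbon is not interchangeable: 3-bromo-4-hydroxyphenyl in place of 4-bromo-3-nitrophenyl gives a 25-fold higher number from compound 2 to compound 3 (1.40 log units; beyond the scatter). This single change removes the nitro group, introduces a hydroxyl and shifts the bromine on the ring, so the step belongs to the whole swap. No measurement at hand accounts for the step.

Which part of the swap carries the step remains open. So does how an amine or a methoxy group in place of the hydroxyl would read.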